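The compounds below may be only part of what the source reports. "The series", "measured", "known", "first", "only" and "open" are said of these compounds alone.

Among the measured compounds shown here, in a functional assay on PC-3 cells (Homo sapiens) for cytotoxicity, read by MTT assay, with a stated time of 48 h (on this read-out lower numbers stand for stronger inhibition and higher numbers for weaker inhibition), compound 2 (`O=C(O)CN1C(=O)/C(=C/c2nc3ccccc3n2Cc2ccc(F)cc2)SC1=S`) gives 4860 nM, the lower of the two numbers so far, while compound 1 (`O=C(O)CN1C(=O)/C(=C/c2nc3ccccc3n2Cc2ccc(Br)cc2F)SC1=S`) gives 21100 nM. Compound 3 (`O=C(O)CN1C(=O)/C(=C/c2nc3ccccc3n2Cc2ccccc2F)SC1=S`) places 2-fluorophenyl in place of 4-fluorophenyl on a saturated chain carbon bound to an aromatic nitrogen. For the measured compounds named here, the only measured step at this place is a 4.3-fold lower number from compound 1 to compound 2 (0.64 log units; beyond the scatter), and it does not isolate this change. With that one modest step as the guide, a modest move toward a higher number in this assay is expected, an estimated 1.4-fold higher number from compound 2 to compound 3 (0.16 log units; within the scatter). For compound 3 the estimated value is 7000 nM, with an expected range of 2500 nM to 20000 nM.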

Compound 3, half-maximal inhibitory concentration: 1860 nM
Compound 3: middle estimate off by 3.8-fold (0.58 log units), on the high side, and the stated range ends above it.
By their numbers in this assay, from the lowest: compound 3; then compound 2; then compound 1.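

In this assay, 2-fluorophenyl in place of 4-fluorophenyl gives a 2.6-fold lower number from compound 2 to compound 3 (0.42 log units; beyond the scatter), so with the same atoms, their arrangement at this position alone moves the number beyond the scatter. Among the compounds shown here, with the 2-fluorophenyl part kept, hydrogen in place of bromo gives an 11-fold lower number from compound 1 to compound 3 (1.05 log units; beyond the scatter), the largest step so far, which isolates the cost of the bromo in this pair. No supporting data explain either step. Going by these compounds, whether unsubstituted benzyl, 2-chlorobenzyl or 2-methoxybenzyl would give a lower or higher number than 2-fluorobenzyl remains open.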